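The compounds below may be only part of what the source reports. "The series", "measured", "known", "first", "only" and "open" are said of these compounds alone.

Compound 1 `CN(Cc1ccccc1)C(=O)C1CCN(C(=O)c2ccc(S(C)(=O)=O)c([N+](=O)[O-])c2)CC1`, compound 2 `CN(Cc1ccccc1F)C(=O)C1CCN(C(=O)c2ccc(S(C)(=O)=O)c([N+](=O)[O-])c2)CC1` and compound 3 `CN(CC(=O)N1CCN(c2ccc(F)cc2)CC1)C(=O)c1ccc(S(C)(=O)=O)c([N+](=O)[O-])c1` share a sulfonyl-nitro aryl amide but carry different amine parts. In an assay on isolated protein for inhibition of thyroid hormone receptor alpha (Homo sapiens), read by fluorescence polarization (a higher number here means a weaker inhibitor, a lower number a stronger inhibitor), compound 1 reaches only the limit of > 60000 nM. Compound 2 likewise gives only a limit, > 60000 nM. Compound 3 also stops at a limit, > 60000 nM. The change from compound 2 to compound 1 is hydrogen in place of fluoro on an aromatic carbon, and its step, a step that the two limits leave unreadable from compound 2 to compound 1, cannot be read because of the limit of > 60000 nM in this assay, at which 3 of the 3 values shown sit. The difference between the cores of compound 2 and compound 3 is not broken down here. Compound 4 `CN(CC(=O)N1CCN(c2ccccc2)CC1)C(=O)c1ccc(S(C)(=O)=O)c([N+](=O)[O-])c1` arises from compound 3 by hydrogen in place of fluoro on an aromatic carbon; this is the same kind of change as before, though the fluoro now sits para to a large group rather than ortho to a large group. The step from compound 3 to compound 4 is expected to be a step that the limit leaves unreadable from compound 3 to compound 4, since all three measured compounds sit at the limit of > 60000 nM in this assay, at which 3 of the 3 values shown sit. Compound 4 is therefore estimated at 100000 nM.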

Compound 4, half-maximal inhibitory concentration: > 60000 nM
Compound 4: no number, only a limit; the forecaster's own chance of this, stated with the estimate: 90%; the middle value does not contradict the limit.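

No size can be read for the change between compound 3 and compound 4, because each gives only a limit, not a number: the limit of > 60000 nM in this assay, at which 4 of the 4 values shown sit. The compounds shown leave open whether replacing fluoro with hydrogen makes any difference in this assay.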